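Swapping the aryl ether in a coumarin-linked pyrazole series

The source may hold more compounds than are shown below. What is called first, only, known or untested is meant among the compounds shown, and "the series" means these compounds.

Measured so far in a functional assay on HepG2 cells (Homo sapiens) for antiproliferative activity, read by MTT assay, with a stated time of 72 h; a higher number here means a weaker inhibitor, a lower number a stronger inhibitor:
- compound 1, `Cc1nn(C)c(Oc2ccc(Br)cc2)c1/C=N\CCCCCOc1cc2oc(=O)cc(C)c2cc1Cl`, gives 13800 nM.
- compound 2, `Cc1nn(C)c(Oc2ccc(F)c(F)c2)c1/C=N\CCCCCCOc1cc2oc(=O)cc(C)c2cc1Cl`, gives > 25000 nM, which is a limit of the assay and not a number.

Where compound 2 stands is therefore only partly known: its inhibition did not reach the measurable window, so it sits at the limit of > 25000 nM in this assay, at which 1 of the 2 values shown sits. Going by the values given here, compound 1 is the sole compound here with an actual number, and no single-change step connects compound 1 to compound 2, so the two values can only be set side by side, with compound 2 the one held at the limit.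

The next compound, compound 3, `Cc1nn(C)c(Oc2ccc(OC(F)(F)F)cc2)c1/C=N\CCCCCCOc1cc2oc(=O)cc(C)c2cc1Cl`, differs from compound 2 in one place: 4-(trifluoromethoxy)phenyl in place of 3,4-difluorophenyl on an oxygen on an aromatic ring. Everything else, including the six-carbon chain to the coumarin side, is kept.

Nothing measured here shows what this exchange of aryl groups does in this assay, so no direction can be drawn from the data. Compound 2 is already at the limit, which leaves little room for a weaker reading to be told apart from it. The step from compound 2 to compound 3 is expected to be a number no higher from compound 2 to compound 3 (the limit leaves the size open), close to none beyond the scatter. Compound 3 is therefore estimated at 25000 nM, with a range from 9000 nM to 70000 nM, and most likely again reported only as a limit.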

Compound 3, half-maximal inhibitory concentration: 8160 nM
Compound 3: the middle estimate sits 3.1-fold (0.49 log units) above what was measured; measured number below the stated range.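

In this assay, the aryl group on the ether oxygen proves able to shift the reading: with the chain and the rest of the molecule kept, 4-(trifluoromethoxy)phenyl in place of 3,4-difluorophenyl gives an at least 3.0-fold lower number from compound 2 to compound 3 (0.48 log units; beyond the scatter). Going by these compounds alone, this is the first single-change comparison, and since compound 3 keeps the chain of compound 2 yet gives a measured number, that chain does not by itself hold a compound at the limit. The step gives only a minimum size, and the true gap may be larger, because compound 2 is held at a limit: the limit of > 25000 nM in this assay, at which 1 of the 3 values shown sits.

With a single exchange at this position, the effect of bringing in the trifluoromethoxy group cannot be separated from that of removing the two ring fluorines, a question that a plain phenyl, a 4-methoxyphenyl or a 4-fluorophenyl on the same oxygen could help to settle. Also open, going by these compounds, is whether the step carries over to other chains, since compound 1 differs from compound 3 in both its chain and its aryl group, and a 4-bromophenyl on the chain of compound 3 would link the two by a single change.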